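The compounds below may be only part of what the source reports. "The series", "measured", "known", "first", "only" and "open" are said of these compounds alone.

Of the compounds shown here, three that share one core have been measured in a functional assay on HT-29 cells (Homo sapiens) for inhibition, read by sulforhodamine B assay, with a stated time of 72 h; on this read-out lower numbers stand for stronger inhibition and higher numbers for weaker inhibition. Compound 1 `COc1ccc(C2C(O)C(=O)N2c2cc(OC)c(OC)c(OC)c2)cc1` gives 12 nM, compound 2 `CCSc1ccc(C2C(O)C(=O)N2c2cc(OC)c(OC)c(OC)c2)cc1` gives 12 nM, and compound 3 `COc1cc(N2C(=O)C(O)C2c2ccc(SC)cc2)cc(OC)c1OC` gives 15 nM. Compound 2 thus stands level with compound 1, and compound 3 lies within the scatter of both.

Compound 4 `CCSc1ccc(C2C(C3CC3)C(=O)N2c2cc(OC)c(OC)c(OC)c2)cc1` keeps the 4-(ethylsulfanyl)phenyl group of compound 2 and changes a different part of the molecule: it has cyclopropyl in place of hydroxy on a saturated ring carbon.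

The measured steps give only indirect help. They are no change at the digits printed from compound 1 to compound 2 (within the scatter), a 1.3-fold higher number from compound 1 to compound 3 (0.10 log units; within the scatter) and a 1.3-fold higher number from compound 2 to compound 3 (0.10 log units; within the scatter), all within the scatter, and all of them concern the group on the aromatic ring. On these data alone, none touches the ring carbon that changes here, and all three measured compounds carry the hydroxy, so its replacement is untested. A flat result at one place says little about another, so the starting point is simply compound 2 at 12 nM.

In this assay, a move toward weaker inhibition is expected, though with wide uncertainty, and the estimated step is a 4.2-fold higher number from compound 2 to compound 4 (0.62 log units; beyond the scatter). For compound 4 the expected value is 50 nM, with an estimated range from 10 nM to 300 nM.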

Compound 4, half-maximal inhibitory concentration: 1560 nM
Beside the measured number, compound 4's estimate is 31-fold (1.49 log units) below it, outside the stated range (above it).
By their numbers in this assay, from the lowest: compounds 1, 2 and 3 (each within the scatter of the next); then compound 4.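

In this assay, cyclopropyl in place of hydroxy on this saturated ring carbon gives a 130-fold higher number from compound 2 to compound 4 (2.11 log units; beyond the scatter). Within the data shown here, this is the first large change: the earlier compounds all carry the hydroxy and differ only in the group on the aromatic ring, with every step within the scatter, so the flat picture there does not extend to this position of the four-membered ring. The change swaps a hydroxy, which counts as a hydrogen-bond donor and acceptor, for a larger all-carbon three-membered ring that counts as neither, and no measurement at hand explains why the number rises so steeply.

With only this one replacement, the compounds shown cannot tell whether the loss follows from removing the hydroxy or from adding the cyclopropyl, and a plain hydrogen, a methyl, a methoxy or an amine on the same ring carbon would help to separate the two. On these data alone, it also remains open whether cyclopropyl at this place would have the same effect with the methoxy of compound 1 on the aromatic ring.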